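This account rests on a few compounds, and the source may have more. Where it says the series, first, only, none or still open, it means among the compounds named here.

Measured so far:
- compound 1 `CN(C)CCCn1c(N)c(-c2nc3ccccc3[nH]2)c2nc(C#N)c(C#N)nc21`: 25900 nM
- compound 2 `CN(C)CCCCCn1c(N)c(-c2nc3ccccc3[nH]2)c2nc(C#N)c(C#N)nc21`: 10800 nM

In a functional assay on HeLa cells (Homo sapiens) for antiproliferative activity, read by MTT assay, with a stated time of 48 h (on this read-out lower numbers stand for stronger inhibition and higher numbers for weaker inhibition), compound 1 gives 25900 nM, the higher of the two numbers. Compound 3 `CN(C)CCCn1c(N)c(-c2nc3ccccc3n2C)c2nc(C#N)c(C#N)nc21` departs from it at one place: methyl in place of hydrogen on an aromatic nitrogen. In short, methyl replaces hydrogen on an aromatic nitrogen. Among the measured compounds shown here, only one measured step exists, a 2.4-fold lower number from compound 1 to compound 2 (0.38 log units; beyond the scatter). It is modest and changes the chain, not this nitrogen, so it suggests a rough size but no direction. No step beyond the scatter is therefore expected in this assay. The estimated step is a 1.2-fold lower number from compound 1 to compound 3 (0.07 log units; within the scatter). For compound 3 the expected value is 22000 nM, with an estimated range of 7000 nM to 60000 nM.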

Compound 3, half-maximal inhibitory concentration: 4320 nM
The estimate for compound 3 lay 5.1-fold (0.71 log units) above the measured number, and the stated range ends above it.
By their numbers in this assay, from the lowest: compound 3; then compound 2; then compound 1.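

Methyl on the aromatic nitrogen gives a 6.0-fold lower number from compound 1 to compound 3 (0.78 log units; beyond the scatter) in this assay and this shows that the ring part of the molecule, not only the chain, can shift the number beyond the scatter. The hydrogen on this nitrogen is therefore not needed for activity in compound 3. Nothing available explains why the number falls.

Going by these compounds, whether ethyl or benzyl on this nitrogen would lower the number further remains open. So does whether methyl would give a similar step on the longer chain of compound 2.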